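Trimming the Benzyl from a Selenium-Bearing Acylimidamide

The compounds below may be only part of what the source reports. "The series", "measured", "known", "first", "only" and "open" are said of these compounds alone.

Of the compounds shown here, three built on a shared acylimidamide core have been tested in a functional assay on HepG2 cells (Homo sapiens) for cytotoxicity, read by MTT assay, with a stated time of 72 h; a lower number here means a stronger inhibitor of growth, a higher number a weaker inhibitor of growth. Compound 1 `CS/C(=N\C(=O)c1ccno1)NC(=O)c1ccno1` carries a methyl group on sulfur; its result in this assay is a limit, > 100000 nM, not a number. Compound 2 `O=C(/N=C(/NC(=O)c1ccno1)[Se]Cc1ccccc1)c1ccno1` carries a benzyl group on selenium instead and gives 58900 nM in this assay. Compound 3 `O=C(/N=C(/NC(=O)c1cc(-c2ccccc2)nc2ccccc12)[Se]Cc1ccccc1)c1cc(-c2ccccc2)nc2ccccc12`, which has the same benzylseleno group on a different core, gives 52400 nM in this assay. Of the two numbers, compound 2 holds the higher one, and compound 3 sits within the scatter of it. The step of an at least 1.6-fold lower number from compound 1 to compound 2 (0.22 log units; that floor lies within the scatter) is known only as a floor because compound 1 sits at the limit (the limit of > 100000 nM in this assay, at which 1 of the 3 values shown sits).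

Compound 4 `C[Se]/C(=N\C(=O)c1ccno1)NC(=O)c1ccno1` is compound 2 with hydrogen in place of phenyl on a saturated chain carbon bound to a selenium atom. For the measured compounds named here, no measured step changes the benzyl alone: the only step touching this position, an at least 1.6-fold lower number from compound 1 to compound 2 (0.22 log units; that floor lies within the scatter), swaps sulfur for selenium and methyl for benzyl at once. Compound 4 stands between compound 1 and compound 2 in structure, so its number is expected to lie between theirs, a rise from compound 2 of a 1.7-fold higher number from compound 2 to compound 4 (0.23 log units; within the scatter). The estimate for compound 4 is 100000 nM, with a range of 40000 nM to 300000 nM, and a fair chance that this assay reports only a limit for it.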

Compound 4, concentration for total growth inhibition: 9350 nM
Compound 4: middle estimate off by 11-fold (1.03 log units), on the high side; the whole stated range lies above it.
By their numbers in this assay, from the lowest: compound 4; then compounds 3 and 2 (each within the scatter of the next). At a limit, above all of these: compound 1.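

In this assay, cutting benzyl to methyl on selenium gives a 6.3-fold lower number from compound 2 to compound 4 (0.80 log units; beyond the scatter), so on this core the phenyl is not needed for growth inhibition, and the smaller group gives the lower number. For the compounds shown here, with methyl now on both sides, sulfur and selenium can be compared on their own, something the earlier step could not offer, as it changed the atom and the group at once: the single swap of sulfur for selenium gives an at least 10-fold lower number from compound 1 to compound 4 (1.02 log units; beyond the scatter). That step is known only as a floor because compound 1 sits at a limit, not at a number: the limit of > 100000 nM in this assay, at which 1 of the 4 values shown sits.

The compounds shown leave open how the number moves between methyl and benzyl and beyond them, for instance with an ethyl group, a longer chain, or a chain ending in an amine on selenium. Also open, from the compounds shown here alone, is whether the same cut from benzyl to methyl would lower the number on the core of compound 3, and so whether this result holds beyond the core of compound 2.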